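From chloro to fluoro: a step behind a limit

The source may hold more compounds than are shown below. What is called first, only, known or untested is meant among the compounds shown, and "the series" means these compounds.

Compound 1 `CC(=NNC(=S)Nc1ccccc1)c1ccccn1` is the plain member of this small series, while compound 2 `CC(=NNC(=S)Nc1ccc(I)cc1)c1ccccn1` and compound 3 `CC(=NNC(=S)Nc1ccc(Cl)cc1)c1ccccn1` each carry a halogen on the aromatic ring. All were tested in an ADME assay on cells (Erythrocyte, Homo sapiens), read by hemolysis, with a stated time of 1 h; on this read-out lower numbers stand for stronger inhibition and higher numbers for weaker inhibition. Compound 1 gives > 10000 nM, which is a limit and not a number. Compound 2 also gives only a limit, > 10000 nM. Compound 3, the starting point here, likewise stands at a limit, > 10000 nM. Everything so far therefore rests on (the limit of > 10000 nM in this assay, at which 3 of the 3 values shown sit).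

Compound 4 `CC(=NNC(=S)Nc1ccc(F)cc1)c1ccccn1` has fluoro in place of chloro on an aromatic carbon, para to a large group: fluoro in place of chloro on an aromatic carbon. The closest precedents are a step that the two limits leave unreadable from compound 1 to compound 3, a step that the two limits leave unreadable from compound 1 to compound 2 and a step that the two limits leave unreadable from compound 2 to compound 3. None of them has a readable size, so they support no direction of change, only the expectation that compound 4 stays at the same limit. The expected step is a step that the limit leaves unreadable from compound 3 to compound 4, with no real change anticipated. For compound 4 the estimated value is 20000 nM, with an expected range from 10000 nM to 60000 nM.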

Compound 4, half-maximal inhibitory concentration: > 10000 nM
Compound 4 ended at the assay's limit (the forecaster's own chance of this, stated with the estimate: 90%); the middle value lies beyond the limit too.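

Compound 4 stays at a limit in this assay, as do compound 1, compound 2 and compound 3, so no step between any of them can be read: the limit of > 10000 nM in this assay, at which 4 of the 4 values shown sit.

The compounds shown leave open how far apart these four really lie in this assay: none of them gives an actual number.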